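Moving the carboxylic acid around the phenoxy ring

A few compounds are considered here, and "the series" means these few. Any claim that something is new, unique, unknown or untested is made for them only; others in the source may bear on it.

Measured so far:
- Compound 1 `Cc1ccccc1-n1nc(C)c2c1NC(=O)[C@H](C)S[C@@H]2c1ccc(Oc2ccccc2C(=O)O)cc1`: "not active" (no number reported)
- Compound 2 `Cc1nn(-c2ccccc2C(F)(F)F)c2c1C(c1ccc(Oc3ccccc3)cc1)SC(C)C(=O)N2`: 2000 nM
- Compound 3 `Cc1nn(-c2ccccc2Cl)c2c1C(c1ccc(Oc3ccccc3)cc1)SC(C)C(=O)N2`: 2700 nM

In an assay on isolated protein for agonist activity at Bile acid receptor (Homo sapiens), read by AlphaScreen, with a stated time of 30 min (a higher number here means that more compound is needed for the effect, a lower number that less compound is needed), compound 1 is reported as "not active" (no number reported), with no number attached, so it stands apart from the two compounds that gave a value. Compound 2 gives 2000 nM in this assay, and compound 3 gives 2700 nM; the step of a 1.4-fold higher number from compound 2 to compound 3 (0.13 log units; within the scatter) lies within the scatter, so these two are treated as alike. Both carry a plain phenoxy group, whereas compound 1 carries a carboxylic acid on that ring.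

Compound 4 `Cc1ccccc1-n1nc(C)c2c1NC(=O)[C@H](C)S[C@@H]2c1ccc(Oc2cccc(C(=O)O)c2)cc1` differs from compound 1 only in this: 3-carboxyphenyl in place of 2-carboxyphenyl on an oxygen on an aromatic ring. Within the data shown here, none of the measured steps touches this change, since no compound with a 3-carboxyphenoxy group has been measured and the only step available concerns a different part of the molecule. The expectation therefore rests on compound 1 being without a reported number and on compounds 2 and 3 lying in the low micromolar range. Compound 4 is estimated to give about 4000 nM in this assay, within a wide range from 600 nM to 30000 nM, with a real chance that it too is reported only as inactive.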

Compound 4, half-maximal effective concentration: "not active" (no number reported)
The entry for compound 4 holds no number, so the estimate cannot be set against anything.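

In this assay, among these compounds, compound 1 gives "not active" (no number reported) and compound 4 gives "not active" (no number reported) and so no step between these two compounds can be read. No measured evidence bears on this result. On these data alone, whether 2-carboxyphenoxy and 3-carboxyphenoxy differ at all in this assay remains open.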